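A Nitro Analogue Against a Shared Cytotoxicity Ceiling

The source may hold more compounds than are shown below. What is called first, only, known or untested is meant among the compounds shown, and "the series" means these compounds.

Compound 1 `O=C(NN=C1CC(c2ccccc2)NC(c2ccccc2)C1)c1ccccc1`, compound 2 `O=C(NN=C1CC(c2ccccc2)NC(c2ccccc2)C1)c1ccc(Cl)cc1` and compound 3 `O=C(NN=C1CC(c2ccccc2)NC(c2ccccc2)C1)c1ccc(C(F)(F)F)cc1` share one core and differ only in the substituent on the benzoyl ring. In a toxicity assay on BJ cells (Homo sapiens) for cytotoxicity, read by MTT assay, with a stated time of 24 h (a lower number here means a stronger inhibitor, a higher number a weaker inhibitor), compound 1 gives > 400000 nM, which is a limit of the assay and not a number. Compound 2 likewise reaches only the limit > 400000 nM in this assay. Compound 3 also stands at a limit in this assay, > 400000 nM, so its place cannot be fixed more closely. Consequently the steps a step that the two limits leave unreadable from compound 1 to compound 2, a step that the two limits leave unreadable from compound 1 to compound 3 and a step that the two limits leave unreadable from compound 2 to compound 3 stay unreadable, all three values resting at the limit of > 400000 nM in this assay, at which 3 of the 3 values shown sit. Compound 4 `O=C(NN=C1CC(c2ccccc2)NC(c2ccccc2)C1)c1ccc([N+](=O)[O-])cc1` carries nitro in place of trifluoromethyl on an aromatic carbon. With every measured step hidden behind the same limit, the estimate for compound 4 means a number no higher from compound 3 to compound 4 (the limit leaves the size open), and a step beyond the scatter is not expected. The estimate for compound 4 in this assay is therefore 400000 nM, expected to lie between 150000 nM and 1000000 nM, most probably reported again only as a limit.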

Compound 4, half-maximal inhibitory concentration: > 400000 nM
Compound 4: no number, only a limit; the forecaster's own chance of this, stated with the estimate: 85%; the middle value lies on the limit itself.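

In this assay compound 4 gives > 400000 nM, again a limit and not a number. Its steps from compound 1, compound 2 and compound 3 therefore cannot be read: the limit of > 400000 nM in this assay, at which 4 of the 4 values shown sit. The compounds shown leave open whether hydrogen, chloro, trifluoromethyl and nitro on the shared core differ at all in this assay.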